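This account rests on a few compounds, and the source may have more. Where it says the series, first, only, none or still open, it means among the compounds named here.

Measured compounds:
compound 1 `COc1cc(N)c(Cl)cc1C(=O)NC1CCN(CC2CCN(C(=O)C(C)(C)N)CC2)CC1` — 2.6 nM
compound 2 `CCCC(N)C(=O)N1CCC(CN2CCC(NC(=O)c3cc(Cl)c(N)cc3OC)CC2)CC1` — 2.57 nM
compound 3 `COc1cc(N)c(Cl)cc1C(=O)NCC(O)CN1CCC(CN2CCC(N)CC2)CC1` — 40.6 nM

In an assay on striatum for inhibition of 5-hydroxytryptamine receptor 4 (Cavia porcellus), read by radioligand binding (on this read-out lower numbers stand for stronger inhibition and higher numbers for weaker inhibition), compound 2 gives the lowest number of the three; compound 1 lies within the scatter of it, while compound 3 gives a clearly higher number. Compound 4 `COc1cc(N)c(Cl)cc1C(=O)NC1CCN(CC2CCN(C(=O)CCN)CC2)CC1` differs from compound 2 by 2-aminoethyl in place of 1-aminobutyl on a carbonyl carbon. Among the measured compounds shown here, one measured step bears on this place: a 1.0-fold lower number from compound 1 to compound 2 (0.01 log units; within the scatter), where the group on the same carbonyl carbon was also exchanged and the number did not move beyond the scatter. A change of the same kind is therefore expected to leave the number near where compound 2 stands, so the step is estimated as a 1.2-fold higher number from compound 2 to compound 4 (0.07 log units; within the scatter). Compound 4 is expected to give 3 nM in this assay, with a range from 1.2 nM to 8 nM.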

Compound 4, half-maximal inhibitory concentration: 9.5 nM
The estimate for compound 4 lay 3.2-fold (0.50 log units) below the measured number; measured number above the stated range.
By their numbers in this assay, from the lowest: compounds 2 and 1 (each within the scatter of the next); then compound 4; then compound 3.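

In this assay, the group on this carbonyl carbon turns out to matter: 2-aminoethyl in place of 1-aminobutyl gives a 3.7-fold higher number from compound 2 to compound 4 (0.57 log units; beyond the scatter), and in place of 1-amino-1-methylethyl it gives a 3.7-fold higher number from compound 1 to compound 4 (0.56 log units; beyond the scatter). The exchange between the two earlier groups had left the number within the scatter, so this position does not accept every aminoalkyl group alike. Nothing shown here explains the rise. The change from 1-aminobutyl to 2-aminoethyl alters both the amine's place in the chain and the chain's length, from 5 heavy atoms to 3, and the compounds shown do not separate these two differences. A 1-aminoethyl or 3-aminopropyl group on the same carbonyl carbon could do so.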